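Pyrimidinone series: amide-nitrogen methylation on a piperazinyl core

A few compounds are considered here, and "the series" means these few. Any claim that something is new, unique, unknown or untested is made for them only; others in the source may bear on it.

The series is measured in a functional assay on HCT-116 cells (Homo sapiens) for inhibition, read by MTT assay, with a stated time of 48 h; a higher number here means a weaker inhibitor, a lower number a stronger inhibitor. Compound 1 `COc1ccc(Nc2ncc3c(n2)N(C2CCCC2)CC(=O)N3C)cc1` gives 12300 nM. Compound 2 `CCN1C(=O)CN(C2CCCC2)c2nc(Nc3ccc(OC)cc3)ncc21` gives 11000 nM. Compound 3 `CN1CCN(c2ccc(Nc3ncc4c(n3)N(C3CCCC3)CC(=O)N4C)cc2)CC1` gives 3290 nM, the lowest of the three numbers, with its steps to the other two both beyond the scatter.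

Two differences are counted among the measured compounds. From compound 1 to compound 2 the change is methyl in place of hydrogen on a saturated chain carbon bound to an amide-type nitrogen in a ring and the step is a 1.1-fold lower number from compound 1 to compound 2 (0.05 log units; within the scatter). From compound 1 to compound 3 the change is 4-methylpiperazin-1-yl in place of methoxy on an aromatic carbon and the step is a 3.7-fold lower number from compound 1 to compound 3 (0.57 log units; beyond the scatter); this is also how the core of compound 3 differs from the core of compound 1.

Compound 4 `CCN1C(=O)CN(C2CCCC2)c2nc(Nc3ccc(N4CCN(C)CC4)cc3)ncc21` has not been measured. It differs from compound 3 by methyl in place of hydrogen on a saturated chain carbon bound to an amide-type nitrogen in a ring. This is the same change as that from compound 1 to compound 2, made on the core of compound 3; the place is the same word for word, and it occurs twice among the compounds shown.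

Within the data shown here, the expected step of a 1.1-fold lower number from compound 3 to compound 4 (0.03 log units; within the scatter) rests on the single earlier example of this change, the step of a 1.1-fold lower number from compound 1 to compound 2 (0.05 log units; within the scatter), which lay within the scatter, so no real shift from compound 3 is expected. Whether the change reads the same on a core carrying 4-methylpiperazin-1-yl is not shown by any measured pair, which widens the range. Compound 4 is expected at 3100 nM, within a range from 1500 nM to 6500 nM.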

Compound 4, half-maximal inhibitory concentration: 7960 nM
The estimate for compound 4 lay 2.6-fold (0.41 log units) below the measured number; measured number above the stated range.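

The change from methyl to ethyl does not carry unchanged between cores in this assay. On the core bearing 4-methylpiperazin-1-yl it gives a 2.4-fold higher number from compound 3 to compound 4 (0.38 log units; beyond the scatter), and the two steps differ: the same change on two cores in this assay, a 1.1-fold lower number (0.05 log units; within the scatter) from compound 1 to compound 2 and a 2.4-fold higher number (0.38 log units; beyond the scatter) from compound 3 to compound 4, 2.7-fold (0.43 log units) apart, beyond the scatter of two such steps

Read the other way round, 4-methylpiperazin-1-yl in place of methoxy gives a 1.4-fold lower number from compound 2 to compound 4 (0.14 log units; within the scatter), so on the ethyl core compound 4 stays within the scatter of compound 2, and the gain seen on the methyl core does not recur: the same change on two cores in this assay, a 3.7-fold lower number (0.57 log units; beyond the scatter) from compound 1 to compound 3 and a 1.4-fold lower number (0.14 log units; within the scatter) from compound 2 to compound 4, 2.7-fold (0.43 log units) apart, beyond the scatter of two such steps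

These two comparisons rest on the same four compounds and so amount to one observation that the two changes do not add up in this set; they show neither how far this holds beyond compound 1, compound 2, compound 3 and compound 4 nor what lies behind it.

Open, on these data alone, is whether a longer chain such as propyl, at the same place, would continue the shift seen on the core of compound 3 or leave the number where it is. Also open, as far as these compounds go, is whether another amine, such as morpholin-4-yl in place of 4-methylpiperazin-1-yl, would show the same dependence on the methyl or ethyl group.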